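Removing the Hydroxy From the Chain of Compound 1

This account rests on a few compounds, and the source may have more. Where it says the series, first, only, none or still open, it means among the compounds named here.

Compound 1 `OC(Cc1cccnc1)c1cc2ccccc2[nH]1` is reported in an assay on isolated protein for inhibition of Indoleamine 2,3-dioxygenase 1 (Homo sapiens), read by spectrophotometry (a higher number here means a weaker inhibitor, a lower number a stronger inhibitor), as "not active" (no number reported), so no number places it on the scale. Compound 2 `O=C(Cc1cccnc1)c1cc2cc(O)ccc2[nH]1`, which differs from it in more than one place, gives in this assay a value of 37000 nM. Compound 3 `c1cncc(CCc2cc3ccccc3[nH]2)c1` keeps the core of compound 1 and shows (hydrogen in place of hydroxy on a saturated chain carbon bound to an aromatic carbon and a saturated chain carbon). Among the measured compounds shown here, no step between measured compounds is available, so neither size nor direction can be read from numbers, and compound 1 itself gives no figure to move from. For compound 3 the expected half-maximal inhibitory concentration in this assay is 70000 nM, estimated to fall between 20000 nM and 250000 nM.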

Compound 3, half-maximal inhibitory concentration: "not active" (no number reported)
The entry for compound 3 holds no number; there is nothing to compare the estimate with.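

Compound 1 and compound 3 both stand without a number, so no step can be read between them. As far as these compounds go, whether swapping the hydroxy for hydrogen changes inhibition remains open. Nothing shown offers any explanatory evidence.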